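Silyl-protected spirocyclic nucleoside analogues: cytotoxicity notes

The source may hold more compounds than are shown below. What is called first, only, known or untested is meant among the compounds shown, and "the series" means these compounds.

Measured so far:
compound 1, `CCOC(=O)NC(=O)NC1=CS(=O)(=O)O[C@@]12[C@@H](CO[Si](C)(C)C(C)(C)C)O[C@@H](n1cc(C)c(=O)n(C)c1=O)[C@@H]2O[Si](C)(C)C(C)(C)C`: 3000 nM
compound 2, `Cc1cn([C@@H]2O[C@@H]3COC4(O)CS(=O)(=O)O[C@@]34[C@H]2O)c(=O)[nH]c1=O`: 100000 nM

Two compounds of the series have been run in a functional assay on CCRF-CEM cells (Homo sapiens); a lower number here means that less compound is tolerated, a higher number that more compound is tolerated. Compound 1 gives 3000 nM and holds the lowest number of the two. Compound 2 gives 100000 nM, a higher number that lies well beyond the scatter of repeated measurements; the two structures differ in several places at once, so no single change can be read from this pair.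

Compound 3, `Cc1cn([C@@H]2O[C@H](CO[Si](C)(C)C(C)(C)C)[C@@]3(OS(=O)(=O)C=C3NC(=O)c3ccccc3)[C@H]2O[Si](C)(C)C(C)(C)C)c(=O)n(C)c1=O`, has not yet been measured. It keeps the shared core of compound 1 together with both silyl groups and the methylated base, and differs from compound 1 only in the acyl part: phenyl in place of (ethoxycarbonyl)amino on a carbonyl carbon. The change sits on a carbonyl carbon whose other neighbour is an amide-type nitrogen.

Among the compounds with values here, no single-change step between measured compounds is available to calibrate this replacement. With compound 1 as the only anchor at 3000 nM, the step of a 1.3-fold higher number from compound 1 to compound 3 (0.12 log units; within the scatter) is expected to stay within the usual scatter, with no firm direction. Compound 3 is therefore expected to give about 4000 nM, in the range 1000 nM to 20000 nM.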

Compound 3, half-maximal cytotoxic concentration: 4910 nM
Estimate against measurement, compound 3: 1.2-fold (0.09 log units) below; the measured number falls inside the stated range.
By their numbers in this assay, from the lowest: compounds 1 and 3 (each within the scatter of the next); then compound 2.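

Phenyl in place of (ethoxycarbonyl)amino on a carbonyl carbon, read in this assay, gives a 1.6-fold higher number from compound 1 to compound 3 (0.21 log units; within the scatter), and this is the first single-change step available in the series. The (ethoxycarbonyl)amino group that leaves carries a hydrogen-bond donor and hydrogen-bond acceptors and has no ring, whereas the phenyl that enters carries neither donor nor acceptor and brings an aromatic ring; at this position, with the shared core, both silyl groups and the methylated base kept, that exchange goes with no difference that can be told from scatter. No measurement at hand explains this outcome.

From the compounds shown here alone, whether the same holds for other groups on this carbonyl carbon, such as an amine, a carboxylic acid or a longer alkyl chain, remains open, since these two acyl parts cover only a small part of what the position could carry. Also open, going by these compounds, is whether this step would read the same on a core that lacks the silyl groups, as a single step says nothing about the rest of the molecule.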